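The source may report more compounds than this note shows. Statements on the series, on what has been measured and on what is new or still open speak of the compounds shown alone.

Measured compounds:
- compound 1 `CCCCOc1ccc(-c2nc3ncccn3c2NC(C)(C)CC(C)(C)C)cc1`: 29000 nM
- compound 2 `CCCCOc1ccc(-c2nc3ncccn3c2NCc2ccc(OC)cc2)cc1`: 55000 nM
- compound 3 `CCCCOc1ccc(-c2nc3ncccn3c2NCc2ccco2)cc1`: 78000 nM

In a toxicity assay on A549 cells (Homo sapiens) for cytotoxicity, read by luminescence and CellTiter-Glo, with a stated time of 48 h (a lower number here means that less compound is tolerated, a higher number that more compound is tolerated), compound 3 gives the highest of the three numbers. The step of a 2.7-fold higher number from compound 1 to compound 3 (0.43 log units; beyond the scatter) lies beyond the scatter, whereas a 1.4-fold higher number from compound 2 to compound 3 (0.15 log units; within the scatter) lies within it, so compound 2 and compound 3 cannot be ordered.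

Compound 4 `CCCCOc1ccc(-c2nc3ncccn3c2NCc2c[nH]cn2)cc1` differs from compound 3 by 1H-imidazol-4-yl in place of furan-2-yl on a saturated chain carbon bound to a nitrogen on an aromatic ring. Within the data shown here, no measured step swaps one five-membered aromatic ring for another at this position. The nearest comparison is a 1.4-fold higher number from compound 2 to compound 3 (0.15 log units; within the scatter), a ring-for-ring change on the same chain carbon, which stayed within the scatter; a 1.9-fold higher number from compound 1 to compound 2 (0.28 log units; within the scatter) also stayed within it. The step of a 1.0-fold higher number from compound 3 to compound 4 (0.01 log units; within the scatter) is therefore expected to be none beyond the scatter.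

For compound 4 the estimate is 80000 nM, with a range from 35000 nM to 180000 nM.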

Compound 4, half-maximal cytotoxic concentration: > 100000 nM
Compound 4: a limit, no number; the forecaster's own chance of this, stated with the estimate: 30%; middle value at least 1.2-fold (0.09 log units) away from the limit.
By their numbers in this assay, from the lowest: compounds 1, 2 and 3 (each within the scatter of the next, the first and the last beyond it). At a limit, above all of these: compound 4.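

In this assay compound 4 gives > 100000 nM, which is a limit and not a number: the limit of > 100000 nM in this assay, at which 1 of the 4 values shown sits.

The steps of an at least 1.2-fold higher number from compound 3 to compound 4 (0.10 log units; that floor lies within the scatter) and an at least 1.8-fold higher number from compound 2 to compound 4 (0.25 log units; that floor lies within the scatter) have floors within the scatter, so 1H-imidazol-4-yl cannot yet be ordered against furan-2-yl or 4-methoxyphenyl on this chain carbon. The step of an at least 3.4-fold higher number from compound 1 to compound 4 (0.53 log units; beyond the scatter) lies beyond the scatter, and it shows that a ring carrying a hydrogen-bond donor can stand here without lowering the number relative to the 1,1,3,3-tetramethylbutyl compound.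

On these data alone, how far compound 4 lies past its limit stays open. Also open, as far as these compounds go, is whether an aliphatic amine or a carboxylic acid on this chain carbon would give a number or a limit in this assay.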